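Long-chain threonine amides with unsaturated acyl groups: cytotoxicity notes

This account rests on a few compounds, and the source may have more. Where it says the series, first, only, none or still open, it means among the compounds named here.

Compound 1, `CCCCCCCCCCCCNC(=O)[C@@H](NC(=O)/C=C/c1ccccc1)[C@@H](C)O`, gives 200000 nM in a functional assay on SW-620 cells (Homo sapiens) for cytotoxicity, read by MTT assay, with a stated time of 48 h; a lower number here means a stronger inhibitor, a higher number a weaker inhibitor.
Compound 2, `C/C=C/C=C/C(=O)N[C@H](C(=O)NCCCCCCCCCCCC)[C@@H](C)O`, gives 200000 nM in this assay.
Compound 3, `CCCCCCCCCCCCCCNC(=O)[C@@H](NC(=O)/C=C/c1ccccc1)[C@@H](C)O`, gives 200000 nM in this assay.

All three measured compounds sit at the same value in this assay. The change from compound 1 to compound 2 is prop-1-en-1-yl in place of phenyl on a double-bonded chain carbon bound to a double-bonded chain carbon and it made a step of no change at the digits printed from compound 1 to compound 2 (within the scatter). The cores of compound 1 and compound 3 differ by ethyl in place of hydrogen on a saturated chain carbon, ten or more bonds along the chain from an amide-type nitrogen, and that change made a step of no change at the digits printed from compound 1 to compound 3 (within the scatter).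

Compound 4, `C/C=C/C=C/C(=O)N[C@H](C(=O)NCCCCCCCCCCCCCC)[C@@H](C)O`, has not yet been measured in this assay. It differs from compound 3 by prop-1-en-1-yl in place of phenyl on a double-bonded chain carbon bound to a double-bonded chain carbon. For the measured compounds named here, this is the same change as the one from compound 1 to compound 2, made on the core of compound 3 rather than on that of compound 1; the place is described in the same words for both pairs. Since the step from compound 1 to compound 2 was no change at the digits printed from compound 1 to compound 2 (within the scatter), and since compound 3 stands at 200000 nM, level with compounds 1 and 2, the step from compound 3 to compound 4 is expected to be no change at the digits printed from compound 3 to compound 4 (within the scatter). Compound 4 is therefore estimated to give 200000 nM in this assay, expected to lie between 100000 nM and 400000 nM. The measurement will show whether the change behaves the same way on the longer chain.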

Compound 4, half-maximal inhibitory concentration: 200000 nM
Compound 4: middle estimate and measured number agree at the digits printed; the measured number falls inside the stated range.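

In this assay, exchanging phenyl for prop-1-en-1-yl on the core of compound 3 gives no change at the digits printed from compound 3 to compound 4 (within the scatter), and this matches the same exchange on the core of compound 1: the same change on two cores in this assay, no change at the digits printed (within the scatter) from compound 1 to compound 2 and no change at the digits printed (within the scatter) from compound 3 to compound 4, 1.0-fold (0.00 log units) apart, within the scatter of two such steps. Ethyl in place of hydrogen on the saturated chain gives no change at the digits printed from compound 2 to compound 4 (within the scatter), and this likewise matches the same change made on the core of compound 1: the same change on two cores in this assay, no change at the digits printed (within the scatter) from compound 1 to compound 3 and no change at the digits printed (within the scatter) from compound 2 to compound 4, 1.0-fold (0.00 log units) apart, within the scatter of two such steps. Across these four compounds, then, each change reads the same on both cores, but all four stand level, so the agreement is only between steps without measurable size and does not show that either change would carry over as a fixed increment on a core where it moves the value.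

The compounds shown leave open whether anything in this series departs from this level in this assay, for example a much shorter or longer chain, an amine or a carboxylic acid at the end of the chain, or a substituted phenyl on the acyl group. They also leave open whether the hydroxyl group of the shared core contributes to the reading, which a compound carrying a methoxy group there could address.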